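The compounds below may be only part of what the source reports. "The series", "measured", "known", "first", "only" and "open" are said of these compounds alone.

Compound 2 `CCCCCCCCCCCCCCN(NC(=O)COC)C(=O)OC(C)(C)C` is the reference point here. In a functional assay on HeLa cells (Homo sapiens) for cytotoxicity, with a stated time of 72 h (on this read-out lower numbers stand for higher toxicity in this test and higher numbers for lower toxicity in this test), compound 2 gives 41900 nM, the lowest of the three numbers measured. Its nearest neighbour is compound 1 `CCCCCCCCCCCCCCN(N)C(=O)OC(C)(C)C`, which in this assay gives 96500 nM; the step of a 2.3-fold lower number from compound 1 to compound 2 (0.36 log units; beyond the scatter) rests on (methoxymethyl)carbonyl in place of hydrogen on an amine nitrogen. Further away is compound 3 `CCCCCCCCCCN(NC(=O)COC)C(=O)OC(C)(C)C`, which in this assay gives 104000 nM; the step of a 2.5-fold higher number from compound 2 to compound 3 (0.39 log units; beyond the scatter) rests on hydrogen in place of butyl on a saturated chain carbon, ten or more bonds along the chain from an amide-type nitrogen.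

Compound 4 `CCCCCCCCCCCCCCNNC(=O)COC` differs from compound 2 by hydrogen in place of tert-butoxycarbonyl on an amine nitrogen. For the measured compounds named here, neither measured step touches the tert-butoxycarbonyl group, so no step bears directly on this change; the two steps that exist, both modest and both elsewhere on the molecule, only show that single changes have moved this assay by modest amounts. On that basis a step of at most modest size is expected for compound 4, with no clear direction, and most likely none beyond the scatter, so that a 1.3-fold higher number from compound 2 to compound 4 (0.12 log units; within the scatter) is the expected outcome. Compound 4 is therefore estimated to give 55000 nM in this assay, within a range from 20000 nM to 150000 nM.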

Compound 4, half-maximal cytotoxic concentration: 59600 nM
Estimate against measurement, compound 4: 1.1-fold (0.03 log units) below; low and high end bracket the measured number.
By their numbers in this assay, from the lowest: compounds 2, 4, 1 and 3 (each within the scatter of the next, the first and the last beyond it).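

Taking the tert-butoxycarbonyl group off the amine nitrogen, whose other neighbours are an amide-type nitrogen and a saturated chain carbon, gives in this assay the step of a 1.4-fold higher number from compound 2 to compound 4 (0.15 log units; within the scatter), the first reading at this position. The numbers of the two compounds cannot be told apart in this assay, even though a whole group with no ring and one double bond gives way to a single hydrogen, so in this pair the tert-butoxycarbonyl group is not required for the number seen with compound 2. Nothing available here accounts for this result.

On these data alone, whether the same nitrogen would give a similar number when carrying a smaller group such as acetyl or methoxycarbonyl, or a larger one such as benzyl, remains open. As far as these compounds go, it is also open whether shortening the chain, as in compound 3, or using a longer chain would move the number in this test once the tert-butoxycarbonyl group is gone.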